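The compounds below may be only part of what the source reports. "The series", "measured", "known", "first", "only" and "open" are said of these compounds alone.

In an ADME assay on the whole organism (plasma, strain BALB/c) for pharmacokinetics, with Mus musculus as the target, at a dose of 5 mg/kg by the oral route (a higher number here means more compound in the circulation at the dose given, a lower number less compound in the circulation), compound 3 `CC(C)c1ccc(S(C)(=O)=O)cc1C#Cc1cc(Cl)ccc1OCC(=O)O` gives 2650 ng.h/mL. Compound 1 `CN(C)S(=O)(=O)c1ccc(F)c(C#Cc2cc(Cl)ccc2OCC(=O)O)c1` gives 4880 ng.h/mL. The gap between compound 3 and compound 1 lies within the scatter. Compound 2 `CCCS(=O)(=O)c1ccc(F)c(C#Cc2cc(Cl)ccc2OCC(=O)O)c1` gives 6140 ng.h/mL. The gap between compound 3 and compound 2 lies beyond the scatter, with compound 3 the lower of the two. Compound 4 `CS(=O)(=O)c1ccc(F)c(C#Cc2cc(Cl)ccc2OCC(=O)O)c1` differs from compound 3 by fluoro in place of isopropyl on an aromatic carbon, with fluoro in place of isopropyl on an aromatic carbon para to a methylsulfonyl group. Within the data shown here, no measured step covers this exchange directly. Among the measured compounds shown here, compounds 1 and 2 carry the fluoro, and the one measured step, a 1.3-fold higher number from compound 1 to compound 2 (0.10 log units; within the scatter), changes only the group on the sulfonyl sulfur. Compound 4 is therefore expected to fall near those two values. The expected change is upward, a 1.7-fold higher number from compound 3 to compound 4 (0.23 log units; within the scatter). The estimate for compound 4 is 4500 ng.h/mL, with an expected range of 2200 ng.h/mL to 9000 ng.h/mL.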

Compound 4, area under the concentration-time curve: 3240 ng.h/mL
The estimate for compound 4 lay 1.4-fold (0.14 log units) above the measured number; measured number inside the range.
By their numbers in this assay, from the lowest: compounds 3, 4, 1 and 2 (each within the scatter of the next, the first and the last beyond it).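

In this assay, among these compounds, fluoro in place of isopropyl on the aromatic carbon para to a methylsulfonyl group stays within the scatter (a 1.2-fold higher number from compound 3 to compound 4 (0.09 log units; within the scatter)), the first reading of this position. Methyl on the sulfonyl sulfur also stays within the scatter of propyl (a 1.9-fold lower number from compound 2 to compound 4 (0.28 log units; within the scatter)) and of dimethylamino (a 1.5-fold lower number from compound 1 to compound 4 (0.18 log units; within the scatter)). No supporting measurement bears on the reason for these results.

Open, from the compounds shown here alone, is whether a methoxy or a chloro at this aromatic carbon would move the number beyond the scatter. Going by these compounds, a morpholine on the sulfonyl sulfur also remains untested here.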